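Notes on the step from compound 2 to compound 3

This account rests on a few compounds, and the source may have more. Where it says the series, first, only, none or still open, it means among the compounds named here.

Of the compounds shown here, two on the shared core have numbers so far. In a functional assay on the whole organism (strain Kunming) with Mus musculus as the target, with a stated time of 0.5 h (a higher number here means that more compound is needed for the effect, a lower number that less compound is needed), compound 1 `COc1cc(OC)c(OC)cc1/C=C/COC(=O)/C=C/c1ccccc1Cl` gives 150 mg/kg as its dose for half-maximal effect. Compound 2 `COc1cc(OC)c(OC)cc1/C=C/COC(=O)/C=C/c1ccc(F)cc1` gives 167 mg/kg on the same read-out. The two numbers lie within the scatter of each other, so compound 2 stands level with compound 1. Among the measured compounds shown here, the one measured step is a 1.1-fold higher number from compound 1 to compound 2 (0.05 log units; within the scatter) and it is the only evidence at this place on the chain.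

Compound 3 `COc1cccc(/C=C/C(=O)OC/C=C/c2cc(OC)c(OC)cc2OC)c1` carries 3-methoxyphenyl in place of 4-fluorophenyl on a double-bonded chain carbon bound to a double-bonded chain carbon and the shared core stays as it is. For the measured compounds named here, no measured compound holds the 3-methoxyphenyl group, so the data offer no direct reading of it. Going by the values given here, with only that single small step to go on, no change beyond the scatter is expected in this assay for this exchange. The expected size is a 1.0-fold lower number from compound 2 to compound 3 (0.02 log units; within the scatter) on this reasoning. Compound 3 is estimated at 160 mg/kg with an expected range from 75 mg/kg to 340 mg/kg in this series.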

Compound 3, dose for half-maximal effect: 247 mg/kg
Compound 3: the middle estimate sits 1.5-fold (0.19 log units) below what was measured, and the stated range covers the measured number.
By their numbers in this assay, from the lowest: compounds 1, 2 and 3 (each within the scatter of the next).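

In this assay, the exchange of 4-fluorophenyl for 3-methoxyphenyl on a double-bonded chain carbon bound to a double-bonded chain carbon gives a 1.5-fold higher number from compound 2 to compound 3 (0.17 log units; within the scatter), and the exchange of 2-chlorophenyl for the same group gives a 1.6-fold higher number from compound 1 to compound 3 (0.22 log units; within the scatter). Before this result the position held only halogen-bearing phenyl groups; 3-methoxyphenyl is the first without a halogen, and with it all three compounds still lie within the scatter of one another, so at this place the read-out does not yet separate a chloro, a fluoro and a methoxy phenyl group. Nothing in hand accounts for the small differences among the three compounds, and no supporting measurement bears on this exchange.

Still open, on these data alone, is whether a group of a different kind at this place, such as an aminophenyl ring, a benzoic acid or a plain alkyl chain in place of the phenyl ring, would move the number beyond the scatter. As far as these compounds go, all three compounds also keep the shared core and the ester chain, so the response to a change anywhere else in the structure, for example an amide in place of the ester, remains unknown.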